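The source may hold more compounds than are shown below. What is called first, only, known or untested is meant among the compounds shown, and "the series" means these compounds.

Working notes on the series. Compound 1 `C=CCn1c(=O)/c(=C\c2ccc(F)c(Br)c2)[nH]c(=O)/c1=C\c1ccccc1OC` and compound 2 `C=CCn1c(=O)/c(=C\c2ccccc2F)[nH]c(=O)/c1=C\c1ccccc1OC` share one core and differ only in the aryl arm on the double-bonded chain carbon. In a functional assay on MCF7 cells (Homo sapiens) for cytotoxicity, read by CCK-8 assay, with a stated time of 72 h (a lower number here means a stronger inhibitor, a higher number a weaker inhibitor), compound 1 is reported as "not active" (no number reported) and carries no number. In this assay, within the data shown here, compound 2 gives 23000 nM, the only number in the set so far, and it places compound 2 as a weak inhibitor. Compound 3 `C=CCn1c(=O)/c(=C\c2ccc(C)cc2)[nH]c(=O)/c1=C\c1ccccc1OC` differs from compound 2 by 4-methylphenyl in place of 2-fluorophenyl on a double-bonded chain carbon bound to an aromatic carbon. No step between two measured compounds exists here, so the size of this change has no precedent within the series; the two results shown say only that one arm gives no activity and the other a weak one. The step from compound 2 to compound 3 is expected to be small, toward weaker inhibition or within the scatter, a 1.3-fold higher number from compound 2 to compound 3 (0.12 log units; within the scatter). Compound 3 is estimated at 30000 nM, with a range from 8000 nM to 100000 nM.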

Compound 3, half-maximal inhibitory concentration: "not active" (no number reported)
Compound 3 has no reported number here; no gap can be computed for the estimate.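

No new step can be read: compound 3 carries no number, so its gap from compound 2 cannot be computed. The compounds shown leave open how far changing the aryl arm on the shared core shifts activity. No measurement here bears on the cause of these results.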